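Swapping an Alkyne for a Furan on Two Related Cores

This account rests on a few compounds, and the source may have more. Where it says the series, first, only, none or still open, it means among the compounds named here.

Measured compounds:
compound 1, `C#Cc1cn([C@@H]2O[C@H](CO)[C@@H](O)[C@H]2O)c2ncnc(C)c12`, 290 nM
compound 2, `Cc1ncnc2c1c(-c1ccoc1)cn2[C@@H]1O[C@H](CO)[C@@H](O)[C@H]1O`, 5320 nM
compound 3, `C#Cc1cn([C@@H]2O[C@H](CO)[C@@H](O)[C@H]2O)c2nc(N)nc(OC)c12`, a limit of the assay, > 20000 nM

In a functional assay on HepG2 cells (Homo sapiens) for antiproliferative activity, read by XTT assay, with a stated time of 72 h (on this read-out higher numbers stand for weaker inhibition and lower numbers for stronger inhibition), compound 1 gives 290 nM, while compound 2 gives 5320 nM. The two differ by one change, (furan-3-yl in place of ethynyl on an aromatic carbon), and that change produced an 18-fold higher number from compound 1 to compound 2 (1.26 log units; beyond the scatter). Compound 3 is built on a different core; how its core differs from the core of compound 1 is not broken down here. For compound 3 this assay reports only a limit, > 20000 nM, which is not a number.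

Compound 4, `COc1nc(N)nc2c1c(-c1ccoc1)cn2[C@@H]1O[C@H](CO)[C@@H](O)[C@H]1O`, differs from compound 3 by furan-3-yl in place of ethynyl on an aromatic carbon. The surroundings of the change read the same as for the step from compound 1 to compound 2, so this is the same change. The expected step is a step that the limit leaves unreadable from compound 3 to compound 4, in the same direction as an 18-fold higher number from compound 1 to compound 2 (1.26 log units; beyond the scatter). Because compound 3 already sits at the limit of > 20000 nM in this assay, at which 1 of the 3 values shown sits, compound 4 is expected to return a limit rather than a number. Compound 4 is estimated at 80000 nM, expected between 20000 nM and 400000 nM.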

Compound 4, half-maximal inhibitory concentration: > 20000 nM
Compound 4: a limit, no number; the forecaster's own chance of this, stated with the estimate: 85%; the middle value does not contradict the limit.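

In this assay compound 4 gives > 20000 nM, a limit of the assay and not a number. Going by these compounds alone, compound 3 and compound 4 both stop at this limit, so no step between them can be read: the limit of > 20000 nM in this assay, at which 2 of the 4 values shown sit.

The compounds shown leave open whether furan-3-yl in place of ethynyl weakens inhibition at all on the core of compound 3, and by how much.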